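Ester chain length and cytotoxicity in one ester series

The source may report more compounds than this note shows. Statements on the series, on what has been measured and on what is new or still open speak of the compounds shown alone.

Three measured esters share one core and differ only in the length of the saturated chain on the ester oxygen. Compound 1 `CCCCCCCOC(=O)CCC(=O)N1CCN(CCCOc2cc3c(Nc4ccc(F)c(Cl)c4)ncnc3cc2OC)CC1` carries the shortest chain, and in a functional assay on A549 cells (Homo sapiens) for cytotoxicity, read by MTT assay, with a stated time of 24 h, tested at 20 uM (on this read-out lower numbers stand for a stronger effect and higher numbers for a weaker effect at the one concentration tested), compound 1 gives 79.9%. Compound 2 `CCCCCCCCOC(=O)CCC(=O)N1CCN(CCCOc2cc3c(Nc4ccc(F)c(Cl)c4)ncnc3cc2OC)CC1` is one carbon longer, and in this assay compound 2 gives 80%. Compound 3 `CCCCCCCCCCCCCOC(=O)CCC(=O)N1CCN(CCCOc2cc3c(Nc4ccc(F)c(Cl)c4)ncnc3cc2OC)CC1` carries the longest chain of the three, and in this assay compound 3 gives 93.8%. The steps of a number 13.9 percentage points higher from compound 1 to compound 3 (beyond the scatter) and a number 13.8 percentage points higher from compound 2 to compound 3 (beyond the scatter) both lie beyond the scatter, so compound 3 stands as the weakest of the three, while the step of a number 0.1 percentage points higher from compound 1 to compound 2 (within the scatter) lies within it.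

The change methyl in place of hydrogen on a saturated chain carbon, seven bonds along the chain from an oxygen next to a carbonyl group occurs twice among these compounds. The measured instance gave a number 0.1 percentage points higher from compound 1 to compound 2 (within the scatter). From compound 3 to compound 4 `CCCCCCCCCCCCCCOC(=O)CCC(=O)N1CCN(CCCOc2cc3c(Nc4ccc(F)c(Cl)c4)ncnc3cc2OC)CC1` the change is methyl in place of hydrogen on a saturated chain carbon, ten or more bonds along the chain from an oxygen next to a carbonyl group. The cores of the two pairs differ by hexyl in place of hydrogen on a saturated chain carbon, seven bonds along the chain from an oxygen next to a carbonyl group. The place is not the same word for word: the carbon that takes the methyl lies further along the chain from the oxygen next to a carbonyl group in the new pair than in the measured pair, so this is the same kind of change rather than the same one.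

For compound 4 the expected step is a number 1.2 percentage points higher from compound 3 to compound 4 (within the scatter), close to no movement, because a number 0.1 percentage points higher from compound 1 to compound 2 (within the scatter) stayed within the scatter. Compound 3 shows with 93.8% that a much longer chain did raise the number, so a small further rise cannot be excluded. Compound 4 is estimated at 95%, between 85% and 104%.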

Compound 4, a percentage reported as activity, at one concentration (the size of the read-out at that concentration, not a potency): 92.3%
Compound 4: middle estimate off by 2.7 percentage points, on the high side; the measured number falls inside the stated range.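

In this assay, methyl on the long chain gives a number 1.5 percentage points lower from compound 3 to compound 4 (within the scatter), and this step reads the same as the methyl step on the shorter chain: the same change on two cores in this assay, a number 0.1 percentage points higher (within the scatter) from compound 1 to compound 2 and a number 1.5 percentage points lower (within the scatter) from compound 3 to compound 4, 1.6 percentage points apart, within the scatter of two such steps

The larger chain extensions also stay close together, with a number 12.3 percentage points higher from compound 2 to compound 4 (beyond the scatter) and a number 12.4 percentage points higher from compound 1 to compound 4 (beyond the scatter), and the hexyl change carries from one core to the other with a matching step: the same change on two cores in this assay, a number 13.9 percentage points higher (beyond the scatter) from compound 1 to compound 3 and a number 12.3 percentage points higher (beyond the scatter) from compound 2 to compound 4, 1.6 percentage points apart, within the scatter of two such steps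

Within these four esters, each repeated change therefore gives a like step on both cores, but this rests on only two pairs per change and does not show a steady dependence on chain length, since the methyl steps stay within the scatter while the longer extensions go beyond it; nor do these steps give any reason for the rise.

The compounds shown leave open where, between the chain of compound 2 and the chain of compound 3, the number begins to rise, and whether a still longer chain would keep it level. They also leave open whether the same steps would hold for an ester chain carrying an amine or a carboxylic acid.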